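Swapping an alkenyl ester chain for a methoxybenzyl group

The source may report more compounds than this note shows. Statements on the series, on what has been measured and on what is new or still open speak of the compounds shown alone.

Among three dihydropyridines tested in a functional assay on HEK293 cells for antagonist activity at Voltage-dependent L-type calcium channel subunit alpha-1C (Oryctolagus cuniculus), read by FLIPR (on this read-out lower numbers stand for stronger inhibition and higher numbers for weaker inhibition), compound 2 `C=C(C)CCOC(=O)C1=C(C)NC(C)=C(C(=O)OC)C1c1cccc([N+](=O)[O-])c1` gives the lowest number, 23 nM. Compound 3 `CCOC(=O)C1=C(C)NC(C)=C(C(=O)OCc2ccc([N+](=O)[O-])cc2)C1c1cccc([N+](=O)[O-])c1` gives 130 nM, and compound 1 `CCOC(=O)C1=C(C)NC(COC(=O)c2ccccc2)=C(C(=O)OCC)C1c1cccc([N+](=O)[O-])c1` gives 210 nM; both sit beyond the scatter above compound 2. Compound 4 `COC(=O)C1=C(C)NC(C)=C(C(=O)OCc2ccc(OC)cc2)C1c1cccc([N+](=O)[O-])c1` has not yet been measured in this assay. It differs from compound 2 in one place: 4-methoxyphenyl in place of 2-methylprop-2-en-1-yl on a saturated chain carbon bound to an oxygen next to a carbonyl group. Going by the values given here, no pair of measured compounds differs in only one place, so no single-change step is available. The expectation is a moderate loss of potency from compound 2 to compound 4, a 3.5-fold higher number from compound 2 to compound 4 (0.54 log units; beyond the scatter), partly because compound 3, which also carries an aromatic ring on this ester, gives 130 nM. Compound 4 is estimated at 80 nM, within 25 nM to 250 nM.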

Compound 4, half-maximal inhibitory concentration: 51 nM
The estimate for compound 4 lay 1.6-fold (0.20 log units) above the measured number; low and high end bracket the measured number.
By their numbers in this assay, from the lowest: compound 2; then compound 4; then compounds 3 and 1 (each within the scatter of the next).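

In this assay, replacing 2-methylprop-2-en-1-yl with 4-methoxyphenyl on a saturated chain carbon bound to an oxygen next to a carbonyl group gives a 2.2-fold higher number from compound 2 to compound 4 (0.35 log units; beyond the scatter). Going by these compounds alone, this is the first single-place reading at this position, and it shows that a larger group with an aromatic ring costs only a modest step here. Nothing available explains the size of this step. The step cannot separate the contribution of the ring from that of its methoxy group. From the compounds shown here alone, how an unsubstituted benzyl group or a chain ending in an amine would compare here remains open.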